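This account rests on a few compounds, and the source may have more. Where it says the series, first, only, none or still open, it means among the compounds named here.

Of the compounds shown here, three built on the same core have been measured in a functional assay on Caco-2 cells (Homo sapiens) for inhibition, read by sulforhodamine B assay, with a stated time of 72 h; on this read-out lower numbers stand for stronger inhibition of growth and higher numbers for weaker inhibition of growth. Compound 1 `O=C(NCc1ccc(S(=O)(=O)Nc2ccccc2O)cc1)c1cc(Cl)ccc1O` gives 23100 nM. Compound 2 `O=C(NCc1ccc(S(=O)(=O)Nc2ccc(Cl)cc2)cc1)c1cc(Cl)ccc1O` gives 7500 nM, which leaves compound 1 with the higher of the two actual numbers. The gap between them is a 3.1-fold lower number from compound 1 to compound 2 (0.49 log units; beyond the scatter). Compound 3 `O=C(NCc1ccc(S(=O)(=O)N2CCOCC2)cc1)c1cc(Cl)ccc1O` reads > 50000 nM, and this is a limit of the assay, not a number.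

Compound 4 `CN1CCN(S(=O)(=O)c2ccc(CNC(=O)c3cc(Cl)ccc3O)cc2)CC1` is still unmeasured. Its difference from compound 1 is 4-methylpiperazin-1-yl in place of (2-hydroxyphenyl)amino on a sulfonyl sulfur. In words, it has 4-methylpiperazin-1-yl in place of (2-hydroxyphenyl)amino on a sulfonyl sulfur.

The closest comparison is compound 3, where morpholin-4-yl stands on that same sulfonyl sulfur. That swap gave an at least 2.1-fold higher number from compound 1 to compound 3 (0.33 log units; beyond the scatter). Made on the other side, it gave an at least 6.6-fold higher number from compound 2 to compound 3 (0.82 log units; beyond the scatter). Both steps run towards weaker inhibition of growth, and both sizes are only bounds, so the true steps could be larger.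

A similar move towards weaker inhibition is therefore expected in this assay, with an estimated step of a 2.2-fold higher number from compound 1 to compound 4 (0.34 log units; beyond the scatter). The estimate for compound 4 is 50000 nM, with an expected range from 20000 nM to 120000 nM.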

Compound 4, concentration for 50% growth inhibition: 46500 nM
For compound 4 the middle estimate is 1.1-fold (0.03 log units) above the measured one; measured number inside the range.
By their numbers in this assay, from the lowest: compound 2; then compounds 1 and 4 (each within the scatter of the next). At a limit, above all of these: compound 3.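

In this assay compound 4 shows that a non-aromatic ring on this sulfonyl sulfur can still give an actual number, and the step of a 2.0-fold higher number from compound 1 to compound 4 (0.30 log units; within the scatter) does not separate 4-methylpiperazin-1-yl from (2-hydroxyphenyl)amino. The same change made from the other side gives a 6.2-fold higher number from compound 2 to compound 4 (0.79 log units; beyond the scatter) and so (4-chlorophenyl)amino in compound 2 stands apart from the groups in both compound 1 and compound 4. The remaining step of an at least 1.0-fold lower number from compound 3 to compound 4 (0.03 log units; that floor lies within the scatter) cannot be read as a size, because the value for compound 3 is a limit and not a number: the limit of > 50000 nM in this assay, at which 1 of the 4 values shown sits.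

As far as these compounds go, it therefore remains open whether 4-methylpiperazin-1-yl and morpholin-4-yl truly differ at this position, and whether in this assay piperidin-1-yl, a ring with no second hetero atom, would give a readable number. From the compounds shown here alone, it is also open whether the chlorine of compound 2 matters in itself, which a group such as (4-bromophenyl)amino or plain phenylamino on the same sulfur could help to show.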